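The source may report more compounds than this note shows. Statements on the series, on what has been measured and on what is new or still open speak of the compounds shown alone.

Among the compounds with values here, compound 1 `CCCCn1cnc2c(Nc3cccc(Cl)c3)nc(NCOCc3ccc(/C=C/C(=O)Nc4ccccc4N)cc3)nc21` stands lowest of the three numbers so far in a functional assay on HCT-116 cells (Homo sapiens) for antiproliferative activity, read by CCK-8 assay, with a stated time of 72 h, tested at 8 uM; on this read-out higher numbers stand for a stronger effect at the one concentration tested and lower numbers for a weaker effect: compound 1 gives 10.9%. Compound 2 `Nc1ccccc1NC(=O)c1ccc(Cn2cnc3c(Nc4ccccc4)nc(Cl)nc32)cc1` gives 83.5% in this assay, and compound 3 `Nc1ccccc1NC(=O)c1ccc(Cn2cnc3c(Nc4ccc(-c5ccccn5)cc4)nc(Cl)nc32)cc1` gives 73.7%; both gaps to compound 1 lie beyond the scatter. Within the data shown here, the single measured step, a number 9.8 percentage points lower from compound 2 to compound 3 (within the scatter), concerns a pyridin-2-yl in place of hydrogen on an aromatic carbon and leaves the substituent on the aromatic nitrogen of the fused core untouched, so it says nothing direct about the change now at hand.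

Compound 4 `CC(C)n1cnc2c(Nc3cccc(Cl)c3)nc(NCOCc3ccc(/C=C/C(=O)Nc4ccccc4N)cc3)nc21` differs from compound 1 by isopropyl in place of butyl on an aromatic nitrogen. Among the measured compounds shown here, no measured pair varies this alkyl group, and the one measured step lay within the scatter, so there is no precedent for a large shift in this assay from a change of this kind. Compound 4 is therefore expected to stay near compound 1, with a step of a number 2.1 percentage points higher from compound 1 to compound 4 (within the scatter) in this assay that should not exceed the scatter. The estimate for compound 4 in this assay is 13%, expected to fall between 0% and 30%.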

Compound 4, a percentage reported as inhibition, at one concentration (the size of the read-out at that concentration, not a potency): 27.9%
The estimate for compound 4 lay 14.9 percentage points below the measured number; the measured number falls inside the stated range.
By their numbers in this assay, from the lowest: compound 1; then compound 4; then compounds 3 and 2 (each within the scatter of the next).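

In this assay, within the data shown here, the first measured change at this position comes out as a number 17 percentage points higher from compound 1 to compound 4 (beyond the scatter) for isopropyl in place of butyl on an aromatic nitrogen. The alkyl group here therefore moves the number beyond the scatter, although neither group holds a ring, a hydrogen-bond donor or a hydrogen-bond acceptor, and they differ by one carbon and in chain shape. Nothing on hand gives a reason for this step.

With only butyl and isopropyl compared, chain length and branching cannot be told apart, and an unbranched propyl chain would separate them. Also open, on these data alone, is how smaller or cyclic groups, such as methyl or cyclopentyl, would read at this nitrogen, and whether the step holds with other groups elsewhere on the shared core.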